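The source may hold more compounds than are shown below. What is called first, only, known or untested is meant among the compounds shown, and "the series" means these compounds.

In a functional assay on SK-MEL-28 cells (Homo sapiens) for inhibition, read by MTT assay, with a stated time of 72 h (a higher number here means a weaker inhibitor, a lower number a stronger inhibitor), compound 1 `CCC(=O)[C@@H](C)c1oc([C@H](C)[C@@H]2O[C@](O)([C@@H](C)c3oc(CC)c(C)c(=O)c3C)[C@@H](C)[C@@H](O)[C@@H]2C)c(C)c(=O)c1C` gives > 100000 nM, which is a limit of the assay. Compound 2 `CCC(=O)[C@H](C)c1oc([C@H](C)[C@@H]2O[C@](O)([C@@H](C)c3oc(CC)c(C)c(=O)c3C)[C@@H](C)[C@@H](O)[C@@H]2C)c(C)c(=O)c1C` gives > 100000 nM, which is also a limit and not a number. Compound 3 `CCC(=O)[C@H](C)c1oc([C@H](C)[C@@H]2O[C@](O)([C@@H](C)c3oc(CC)c(C)c(=O)c3C)[C@@H](C)[C@@H](OC(=O)CC(C)C)[C@@H]2C)c(C)c(=O)c1C` follows from compound 2 through (isobutylcarbonyl in place of hydrogen on an oxygen on a saturated carbon), read one bond further out as hydroxy to (isobutylcarbonyl)oxy. Going by the values given here, the only measured step, a step that the two limits leave unreadable from compound 1 to compound 2, concerns the fact that compounds 1 and 2 differ only in the configuration as drawn and rests on (the limit of > 100000 nM in this assay, at which 2 of the 2 values shown sit), so it offers no size to carry over. The expected step is therefore modest and only tentatively toward stronger inhibition, an at least 1.2-fold lower number from compound 2 to compound 3 (0.09 log units; that floor lies within the scatter), and another limit would be no surprise. For compound 3 the estimate is 80000 nM, with an expected range of 25000 nM to 200000 nM.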

Compound 3, half-maximal inhibitory concentration: 23000 nM
Compound 3: middle estimate off by 3.5-fold (0.54 log units), on the high side; the whole stated range lies above it.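

In this assay, going by these compounds alone, the earlier compounds offered no step that could be read, as their one change, in configuration, left both at a limit. Within the data shown here, replacing hydrogen with isobutylcarbonyl on the oxygen on a saturated carbon gives the first readable step at this position, an at least 4.3-fold lower number from compound 2 to compound 3 (0.63 log units; beyond the scatter), so this change does lower the number. From the compounds shown here alone, compound 2 gives > 100000 nM, a limit of the assay and not a number, so the true size of the step stays unknown.

Going by these compounds, whether acetyl or a longer chain on the same oxygen would do the same remains open. So does whether the configuration that separates compound 1 from compound 2 matters once (isobutylcarbonyl)oxy is present.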